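Acid to Amide at the Core of a Thiazole Series

A few compounds are considered here, and "the series" means these few. Any claim that something is new, unique, unknown or untested is made for them only; others in the source may bear on it.

Compound 1 `CN1CCN(c2ccc(Nc3nc(-c4cccc(NC(=O)c5ccccc5F)c4)sc3C(=O)O)cc2)CC1` gives 6300 nM in a functional assay on Ramos cells (Homo sapiens) for antiproliferative activity, read by CCK-8 assay, with a stated time of 72 h (on this read-out higher numbers stand for weaker inhibition and lower numbers for stronger inhibition), the second highest number among the three measured compounds. Compound 3 `CN1CCN(c2ccc(Nc3nc(-c4cccc(NC(=O)c5ccc(F)c(Cl)c5)c4)sc3C(=O)O)cc2)CC1` gives 5600 nM, and compound 2 `CN1CCN(c2ccc(Nc3nc(-c4cccc(NC(=O)c5ccc(Cl)cc5)c4)sc3C(=O)O)cc2)CC1` gives 23300 nM; the steps of a 1.1-fold lower number from compound 1 to compound 3 (0.05 log units; within the scatter) and a 3.7-fold higher number from compound 1 to compound 2 (0.57 log units; beyond the scatter) both concern the phenyl on the carbonyl carbon of the benzamide, not the acid. Compound 4 `CN1CCN(c2ccc(Nc3nc(-c4cccc(NC(=O)c5ccccc5F)c4)sc3C(N)=O)cc2)CC1` differs from compound 1 by amino in place of hydroxy on a carbonyl carbon. Going by the values given here, no measured step touches this position, so the three compounds offer no direct guide to its size or direction. Compound 4 is therefore expected to sit near compound 1, at an estimated 4000 nM with a range from 800 nM to 20000 nM, which would be a step of a 1.6-fold lower number from compound 1 to compound 4 (0.20 log units; within the scatter).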

Compound 4, half-maximal inhibitory concentration: 1360 nM
Compound 4: the middle estimate sits 2.9-fold (0.47 log units) above what was measured; the range from low to high includes it.
By their numbers in this assay, from the lowest: compound 4; then compounds 3 and 1 (each within the scatter of the next); then compound 2.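

Going by these compounds alone, the carbonyl carbon, which no earlier step touched, proves to be a position that moves the read-out in this assay: carboxy to carbamoyl gives a 4.6-fold lower number from compound 1 to compound 4 (0.67 log units; beyond the scatter). In this pair the carboxy group is therefore not needed for antiproliferative activity, and the phenyl on the benzamide carbonyl is not the only place where a single change shifts the number. Nothing available explains this shift. From the compounds shown here alone, whether a methylamino or methoxy group on the same carbonyl carbon would do the same remains open. So does whether carbamoyl gives a similar step alongside the 4-chlorophenyl of compound 2 or the 3-chloro-4-fluorophenyl of compound 3.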